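The source may hold more compounds than are shown below. What is called first, only, known or untested is meant among the compounds shown, and "the series" means these compounds.

Measured compounds in the series:

- compound 1, `COc1ccc(-n2cc(-c3ccc(OC)c(OC)c3)nn2)c(OC)c1`, in a functional assay on MDA-MB-231 cells (Homo sapiens) for cytotoxicity, read by MTT assay; on this read-out higher numbers stand for weaker inhibition and lower numbers for stronger inhibition: "not determined" (no result reported)
- compound 2, `COc1ccc(-n2cc(-c3ccc(OC)c(OC)c3)nn2)cc1`, in this assay: > 100 nM

Compound 2 stands at a limit rather than at a number: in this assay compound 2 gives > 100 nM, which is a limit of the measurement. That value is the limit of > 100 nM in this assay, at which 1 of the 2 values shown sits; the other entry, for compound 1, carries no number at all. Among the compounds with values here, no pair of measured compounds differs in a single place, so no measured step is available to gauge how a change on the shared core moves the read-out.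

Compound 3, `COc1ccc(-c2cn(-c3ccc(Oc4ccccc4)cc3)nn2)cc1OC`, is the next compound to be measured. It differs from compound 2 by phenyl in place of methyl on an oxygen on an aromatic ring. Within the data shown here, with no measured step to draw on, the expected size of this step is none beyond the scatter; the most likely outcome is that compound 3 again sits at the limit of this assay. The expected step is a step that the limit leaves unreadable from compound 2 to compound 3. Compound 3 is accordingly estimated at 300 nM, with a range from 100 nM to 3000 nM.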

Compound 3, half-maximal inhibitory concentration: 10000 nM
Estimate against measurement, compound 3: 33-fold (1.52 log units) below; measured number above the stated range.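

No step can be read from compound 2 to compound 3 in this assay, because compound 2 gives a limit and not a number: the limit of > 100 nM in this assay, at which 1 of the 3 values shown sits.

The compounds shown leave open how far the change from methoxy to phenoxy moves the read-out, and how any other single change on the shared core would move it.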